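The source may hold more compounds than are shown below. What is called first, only, known or untested is meant among the compounds shown, and "the series" means these compounds.

Measured compounds in a functional assay on CHO cells for agonist activity at Free fatty acid receptor 1 (Homo sapiens); a higher number here means that more compound is needed for the effect, a lower number that less compound is needed:
- compound 1 `O=C(O)CCCc1ccc(NCc2cccc(Oc3ccccc3)c2)cc1` gives 1120 nM
- compound 3 `O=C(O)/C=C/c1ccc(NCc2cccc(Oc3ccccc3)c2)cc1` gives 145 nM
- compound 2 `Cc1nc(-c2ccc(C(F)(F)F)cc2)sc1CNc1ccc(CCCC(=O)O)cc1` gives < 10000 nM; this is a limit of the assay, not a number the limit of < 10000 nM in this assay, at which 1 of the 3 values shown sits.

Compound 1 and compound 3 share one core and differ in one place: 2-carboxyethenyl in place of 3-carboxypropyl on an aromatic carbon. The step is a 7.7-fold lower number from compound 1 to compound 3 (0.89 log units; beyond the scatter). No cause for this step is given by the data.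

Compound 2 carries a different core. The difference between the cores of compound 1 and compound 2 is not broken down here. Compound 4 `Cc1nc(-c2ccc(C(F)(F)F)cc2)sc1CNc1ccc(/C=C/C(=O)O)cc1` is built on the core of compound 2 and is not yet measured in this assay.

Compound 4 differs from compound 2 in this way: 2-carboxyethenyl in place of 3-carboxypropyl on an aromatic carbon. The place line reads the same as for the step from compound 1 to compound 3, so this is the same change, seen a second time on another core. Within the data shown here, the expectation for compound 4 rests on the step of a 7.7-fold lower number from compound 1 to compound 3 (0.89 log units; beyond the scatter) as the only measured example of this change. Since compound 2 is known only as a limit (the limit of < 10000 nM in this assay, at which 1 of the 3 values shown sits), the starting point is uncertain, and the expected step from compound 2 to compound 4 is given as a step that the limit leaves unreadable from compound 2 to compound 4, on the assumption that the change carries over in direction and roughly in size. The estimated value for compound 4 in this assay is 1000 nM, with an expected range from 150 nM to 6000 nM.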

Compound 4, half-maximal effective concentration: 36.3 nM
Compound 4: the middle estimate sits 28-fold (1.44 log units) above what was measured; the measured number lies below the stated range.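

No new step can be read between compound 2 and compound 4 in this assay, since compound 2 is held only as a limit: the limit of < 10000 nM in this assay, at which 1 of the 4 values shown sits.

The compounds shown leave open whether a 7.7-fold lower number from compound 1 to compound 3 (0.89 log units; beyond the scatter) carries over in size to the core of compound 2, where the same change, 2-carboxyethenyl in place of 3-carboxypropyl, has no readable starting value.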